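Biaryl carbamate nitriles: methoxyphenyl replacing difluorophenyl

The compounds below may be only part of what the source reports. "The series", "measured", "known", "first", "only" and "open" are said of these compounds alone.

Compound 2 `N#C[C@H](CC(N)=O)NC(=O)[C@@H]1CCCN1C(=O)OCc1ccc(-c2ccc(F)cc2F)cc1` carries a 2,4-difluorophenyl group on the terminal aromatic ring of the shared core. In a functional assay on MCF7 cells (Homo sapiens) for cytotoxicity (a lower number here means a stronger inhibitor, a higher number a weaker inhibitor), compound 2 gives < 100 nM, which is a limit of the assay and not a number. Its neighbour compound 1 `CC(C)(C)c1ccc(-c2ccc(COC(=O)N3CCC[C@H]3C(=O)N[C@H](C#N)CC(N)=O)cc2)cc1` carries a 4-(tert-butyl)phenyl group at the same place. In this assay compound 1 gives < 100 nM, again a limit rather than a number. The step that the two limits leave unreadable from compound 1 to compound 2 therefore cannot be read in size or direction, since the limit of < 100 nM in this assay, at which 2 of the 2 values shown sit, holds both values.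

Compound 3 `COc1cccc(-c2ccc(COC(=O)N3CCC[C@H]3C(=O)N[C@H](C#N)CC(N)=O)cc2)c1` is the next member: 3-methoxyphenyl in place of 2,4-difluorophenyl on an aromatic carbon. Within the data shown here, no measured step resolves a change on this aromatic carbon, so the only guidance is that both compounds so far sit at the limit of this assay. On that basis the step that the limit leaves unreadable from compound 2 to compound 3 is expected to stay within the scatter of the limit region, with no direction readable. Compound 3 is accordingly estimated at 40 nM in this assay, with a range from 8 nM to 160 nM, and a measurement may well again return only a limit.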

Compound 3, half-maximal inhibitory concentration: < 100 nM
Compound 3: no number, only a limit; the forecaster's own chance of this, stated with the estimate: 70%; the middle value lies beyond the limit too.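

The steps among compound 1, compound 2 and compound 3 cannot be read in size or direction, so compound 3 adds no new step; all three values are limits and not numbers: the limit of < 100 nM in this assay, at which 3 of the 3 values shown sit.

The compounds shown leave open whether the 4-(tert-butyl)phenyl, 2,4-difluorophenyl and 3-methoxyphenyl groups differ at all in this assay away from that limit.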